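This account rests on a few compounds, and the source may have more. Where it says the series, first, only, none or still open, it means among the compounds named here.

In this assay an assay on isolated protein for inhibition of serine/threonine-protein kinase TNNI3K (Homo sapiens) (on this read-out lower numbers stand for stronger inhibition and higher numbers for weaker inhibition), compound 2 `CNc1cc(Oc2ccc(NC(=O)Nc3ccccc3)cc2)ncn1` gives 6300 nM, the highest of the three numbers available. Compound 1 `CNc1cc(Oc2ccc(NC(=O)Nc3cccc(C(F)(F)F)c3)cc2Cl)ncn1` gives 50 nM and compound 3 `CNc1nccc(Oc2ccc(NC(=O)Nc3cccc(C(F)(F)F)c3)cc2)n1` gives 50 nM; each of these lies far beyond the scatter from compound 2, and each carries a trifluoromethyl group on its terminal ring that compound 2 lacks, together with other differences. Compound 4 `CNc1cc(Oc2ccc(NC(=O)Nc3cccc(C(C)(C)C)c3)cc2)ncn1` differs from compound 2 by tert-butyl in place of hydrogen on an aromatic carbon. Among the measured compounds shown here, no measured pair isolates exactly this change. Compound 4 is expected to shift toward stronger inhibition by a large step, a 42-fold lower number from compound 2 to compound 4 (1.62 log units; beyond the scatter), since compound 1 with a substituted terminal ring gives 50 nM. The estimate for compound 4 is 150 nM, with a range from 30 nM to 800 nM.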

Compound 4, half-maximal inhibitory concentration: 40 nM
Compound 4: the middle estimate sits 3.8-fold (0.57 log units) above what was measured, and the stated range covers the measured number.
By their numbers in this assay, from the lowest: compounds 4, 1 and 3 (each within the scatter of the next); then compound 2.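

In this assay tert-butyl in place of hydrogen on an aromatic carbon, meta to a large group, gives a 160-fold lower number from compound 2 to compound 4 (2.20 log units; beyond the scatter) as a single change. Among the compounds shown here, in the earlier compounds, substitution on this ring always came with other differences, whereas here a group of carbon alone, with no hydrogen-bond donors or acceptors, produces a large step beyond the scatter. Nothing available explains the size of this step. From the compounds shown here alone, whether methyl, an amine or a carboxylic acid on this carbon would give a comparable step remains open. So does whether tert-butyl would act alike on the core of compound 3.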